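Removing the Hydroxyl from the Side Chain of Compound 3

A few compounds are considered here, and "the series" means these few. Any claim that something is new, unique, unknown or untested is made for them only; others in the source may bear on it.

Compound 3 `COc1cc2ccc(=O)oc2cc1OCC(O)CNC(C)C` stands, among the three numbers in hand, at the low end together with compound 1 `COc1cc2ccc(=O)oc2cc1OCC(O)CN1CCCC1` and far from compound 2 `COc1cc2ccc(=O)oc2cc1OCC(O)CN1CCCCC1`. In a functional assay on HUVEC cells (Homo sapiens) for inhibition, read by MTT assay, with a stated time of 24 h, tested at 100 uM (a higher number here means more inhibition of growth at the concentration tested, a lower number less inhibition of growth), compound 3 gives 6.3%, compound 1 gives 0.3% and compound 2 gives 80.7%. The step of a number 6 percentage points higher from compound 1 to compound 3 (within the scatter) lies within the scatter, whereas the step of a number 74.4 percentage points lower from compound 2 to compound 3 (beyond the scatter) lies well beyond it.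

Compound 4 `COc1cc2ccc(=O)oc2cc1OCCNC(C)C` differs from compound 3 in one place only: (isopropylamino)methyl in place of 1-hydroxy-2-(isopropylamino)ethyl on a saturated chain carbon bound to an oxygen on an aromatic ring. The isopropylamine stays; the hydroxyl on the chain is gone.

For the measured compounds named here, none of the measured steps touches this place. All three change the amine at the end of the chain: a number 80.4 percentage points higher from compound 1 to compound 2 (beyond the scatter) was large, a number 74.4 percentage points lower from compound 2 to compound 3 (beyond the scatter) was large, and a number 6 percentage points higher from compound 1 to compound 3 (within the scatter) stayed within the scatter. They carry no information about the chain between the aromatic oxygen and the nitrogen. The expectation for compound 4 therefore rests on the value of compound 3 alone, and the step of a number 1.7 percentage points higher from compound 3 to compound 4 (within the scatter) is expected to be none beyond the scatter. Compound 4 is estimated to give 8% in this assay, with a range from 0% to 30%.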

Compound 4, percent growth inhibition at one concentration: 0.1%
The estimate for compound 4 lay 7.9 percentage points above the measured number, and the stated range covers the measured number.
By their numbers in this assay, from the lowest: compounds 4, 1 and 3 (each within the scatter of the next); then compound 2.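

Replacing 1-hydroxy-2-(isopropylamino)ethyl with (isopropylamino)methyl on a saturated chain carbon bound to an oxygen on an aromatic ring gives, in this assay, a number 6.2 percentage points lower from compound 3 to compound 4 (within the scatter). For the compounds shown here, this is the first reading on the chain itself rather than on the amine: with isopropylamino at its end, a side chain of 5 heavy atoms in place of 7, with no hydroxyl and with 1 hydrogen-bond donor in place of 2, leaves the growth inhibition at the low end of the series, so this change did not bring out the high number seen with compound 2. No evidence on why the two compounds read alike is available here.

The change removes the hydroxyl and shortens the carbon count from 5 carbon to 4 carbon in one step, so the two cannot be told apart, and a methoxy or a carbonyl in place of the hydroxyl would address the oxygen alone. From the compounds shown here alone, whether the hydroxyl counts when the chain ends in piperidin-1-yl, as in compound 2, remains open, since a step read at the low end says nothing about a chain carrying that amine.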